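The source may report more compounds than this note shows. Statements on the series, on what has been measured and on what is new or still open speak of the compounds shown alone.

Measured compounds in this series:

- compound 3 `Cc1cccc(-c2cn3ccnc3c(-c3ccc4ncn(Cc5ccccc5)c4c3)n2)c1`: 24.8%
- compound 2 `CCc1ccc(-c2cn3ccnc3c(-c3ccc4ncn(Cc5ccccc5)c4c3)n2)cc1`: 50.4%
- compound 1 `O=Cc1ccc(-c2cn3ccnc3c(-c3ccc4ncn(C5CCCCC5)c4c3)n2)cc1`: 19%

In a functional assay on PC-3 cells (Homo sapiens) for inhibition, read by sulforhodamine B assay, with a stated time of 48 h, tested at 10 uM (on this read-out higher numbers stand for more inhibition at the one concentration tested (going by the name of the read-out) and lower numbers for less inhibition), compound 3 gives 24.8%, the second highest of the three numbers; compound 1 gives 19%, which lies within the scatter of compound 3, while compound 2 gives 50.4%, beyond it. Among the compounds with values here, the one measured step at the aryl position, a number 25.6 percentage points lower from compound 2 to compound 3 (beyond the scatter), shows that changing this group can move the read-out by a modest amount.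

Compound 4 `O=Cc1ccc(-c2cn3ccnc3c(-c3ccc4ncn(Cc5ccccc5)c4c3)n2)cc1` is not yet measured. It differs from compound 3 by 4-formylphenyl in place of 3-methylphenyl on an aromatic carbon. Within the data shown here, no measured step covers this particular exchange; the only other compound carrying 4-formylphenyl, compound 1, bears cyclohexyl in place of benzyl and gives a value within the scatter of compound 3. On that basis no step beyond the scatter is expected, and the estimated step is a number 2.8 percentage points lower from compound 3 to compound 4 (within the scatter). Compound 4 is therefore expected to give about 22%, with a range from 8% to 40%.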

Compound 4, a percentage reported as inhibition, at one concentration (the size of the read-out at that concentration, not a potency): 19%
Compound 4: middle estimate off by 3 percentage points, on the high side; low and high end bracket the measured number.
By their numbers in this assay, from the lowest: compounds 1, 4 and 3 (each within the scatter of the next); then compound 2.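

In this assay, with benzyl held on the aromatic nitrogen, 4-formylphenyl and 3-methylphenyl on the aromatic carbon are not told apart: the exchange gives a number 5.8 percentage points lower from compound 3 to compound 4 (within the scatter). Formyl in place of ethyl gives a number 31.4 percentage points lower from compound 2 to compound 4 (beyond the scatter), so among these three groups only 4-ethylphenyl stands apart, and the read-out at this position depends on the group and does not fall with every exchange. Within the data shown here, the first comparison at the aromatic nitrogen, benzyl in place of cyclohexyl, gives no change at the digits printed from compound 1 to compound 4 (within the scatter), so with 4-formylphenyl in place, these two groups are not told apart.

Still open, as far as these compounds go, is whether the value of compound 2 comes from ethyl itself or from its place on the ring, and how an amine, a carboxylic acid or a propyl chain would read at this position. No available evidence accounts for any of these steps.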